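The source may report more compounds than this note shows. Statements on the series, on what has been measured and on what is new or still open speak of the compounds shown alone.

Compound 3 `Cc1ccc(C(=O)CCCN2CCC(C(O)(c3ccccc3)c3ccccc3)CC2)cc1` gives 700 nM in an in vitro assay on Sf9 cells for inhibition of cytochrome P450 2J2 (Homo sapiens); a lower number here means a stronger inhibitor, a higher number a weaker inhibitor; among the three measured compounds it holds the second highest number, lying within the scatter of compound 1 `C=CCc1ccc(C(=O)CCCN2CCC(C(O)(c3ccccc3)c3ccccc3)CC2)cc1` at 400 nM and of compound 2 `O=C(CCCN1CCC(C(O)(c2ccccc2)c2ccccc2)CC1)c1ccc(CCO)cc1` at 1300 nM. Compound 4 `O=C(CCCN1CCC(C(O)(c2ccccc2)c2ccccc2)CC1)c1ccc(CC(F)F)cc1` differs from compound 3 by difluoromethyl in place of hydrogen on a saturated chain carbon bound to an aromatic carbon. Within the data shown here, two measured steps touch the same place: a 1.8-fold higher number from compound 1 to compound 3 (0.24 log units; within the scatter) and a 1.9-fold lower number from compound 2 to compound 3 (0.27 log units; within the scatter), both small, whereas a 3.3-fold higher number from compound 1 to compound 2 (0.51 log units; beyond the scatter). Changes at this chain carbon have so far moved this assay only modestly, and a hydroxymethyl is the only one to go beyond the scatter. The analyst therefore expects no more than a small shift for compound 4, a 1.4-fold lower number from compound 3 to compound 4 (0.15 log units; within the scatter). The estimate for compound 4 is 500 nM, between 200 nM and 1300 nM.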

Compound 4, half-maximal inhibitory concentration: 2200 nM
The estimate for compound 4 lay 4.4-fold (0.64 log units) below the measured number, outside the stated range (above it).
By their numbers in this assay, from the lowest: compounds 1, 3, 2 and 4 (each within the scatter of the next, the first and the last beyond it).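

In this assay, difluoromethyl on this saturated chain carbon bound to an aromatic carbon gives a 3.1-fold higher number from compound 3 to compound 4 (0.50 log units; beyond the scatter), so a group other than hydroxymethyl also moves the number beyond the scatter here. Replacing vinyl with difluoromethyl gives a larger step, a 5.5-fold higher number from compound 1 to compound 4 (0.74 log units; beyond the scatter), whereas replacing hydroxymethyl with difluoromethyl gives only a 1.7-fold higher number from compound 2 to compound 4 (0.23 log units; within the scatter). Nothing in the data shown explains these shifts. On these data alone, it remains open whether an amine, a carboxylic acid or a longer chain at this carbon would give a number nearer that of compound 1 or that of compound 4.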